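From Nitrile to Cyanophenyl on a Shared Core

The source may hold more compounds than are shown below. What is called first, only, known or untested is meant among the compounds shown, and "the series" means these compounds.

Measured compounds:
compound 1, `CCOc1cccnc1Nc1cccc(C)n1` — 40 nM
compound 2, `CCOc1c(C)ccnc1Nc1cccc(C)n1` — 2700 nM
compound 3, `CCOc1cc(C#N)cnc1Nc1cccc(C)n1` — 46 nM

Of the compounds shown here, three with a shared core have been measured in an assay on Ltk cells with metabotropic glutamate receptor 5 (Homo sapiens) as the target, read by fluorescence and calcium flux; a higher number here means a weaker inhibitor, a lower number a stronger inhibitor. Compound 3 stands second highest of the three numbers: its value lies within the scatter of compound 1, while compound 2 shows a far higher number that is well beyond the scatter.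

Compound 4, `CCOc1cc(-c2ccccc2C#N)cnc1Nc1cccc(C)n1`, has not yet been measured. It differs from compound 3 by 2-cyanophenyl in place of cyano on an aromatic carbon. For the measured compounds named here, two measured steps bear on this change. The step of a 1.2-fold higher number from compound 1 to compound 3 (0.06 log units; within the scatter) shows that placing a cyano group at this position leaves the number essentially unchanged, so the position accepts a small substituent. The step of a 68-fold higher number from compound 1 to compound 2 (1.83 log units; beyond the scatter) shows that a methyl group elsewhere on the same ring is followed by a large loss, so the core is not indifferent to added groups. Going by the values given here, no measured compound carries a group as large as 2-cyanophenyl anywhere, so the outcome is open. The expectation is a moderate weakening, a 3.3-fold higher number from compound 3 to compound 4 (0.51 log units; beyond the scatter), with wide uncertainty. Compound 4 is estimated at 150 nM, within a range from 25 nM to 1200 nM.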

Compound 4, half-maximal inhibitory concentration: 37 nM
The estimate for compound 4 lay 4.1-fold (0.61 log units) above the measured number; measured number inside the range.
By their numbers in this assay, from the lowest: compounds 4, 1 and 3 (each within the scatter of the next); then compound 2.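

In this assay, for the compounds shown here, the position two atoms from the ring nitrogen proves far more accommodating than the earlier compounds could show: a 1.2-fold lower number from compound 3 to compound 4 (0.09 log units; within the scatter) and a 1.1-fold lower number from compound 1 to compound 4 (0.03 log units; within the scatter) both lie within the scatter. Compound 3 had shown only that this position accepts cyano, whereas compound 4 extends that to 2-cyanophenyl, a group of 8 heavy atoms with a six-membered aromatic ring of carbon only, and the number still stays level with those of the smaller or absent substituent. Nothing in the available data accounts for this tolerance.

Still open, as far as these compounds go, is whether it depends on the nitrile of the 2-cyanophenyl group, which a plain phenyl group at this position would test, and whether it extends to an amine or a carboxylic acid there. The large step of a 68-fold higher number from compound 1 to compound 2 (1.83 log units; beyond the scatter) also stands alone, so it remains unsettled whether a fluorine atom or a methoxy group in place of that methyl would be followed by a similar loss.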